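Acetylation of the Free Hydroxy Group of Compound 3

This account rests on a few compounds, and the source may have more. Where it says the series, first, only, none or still open, it means among the compounds named here.

Three measured compounds share one core. Compound 1 `CCCCCCCCO[C@@H]1O[C@@H](C)[C@H](OC(=O)CCCCC)[C@@H](O[C@@H]2O[C@@H](C)[C@H](OC(C)=O)[C@@H](O[C@@H]3O[C@@H](C)[C@H](O)[C@@H](O)[C@H]3OC(C)=O)[C@H]2OC(C)=O)[C@H]1O` has been tested in a functional assay on KB cells (Homo sapiens) for cytotoxicity, in the presence of a further agent that is not named here; a lower number here means that less compound is needed, a higher number that more compound is needed for the effect. In this assay compound 1 gives > 20 ug/mL, which is a limit of the assay rather than a number. Compound 2 `CCCCCCCCO[C@@H]1O[C@@H](C)[C@H](OC(=O)CCCCC)[C@@H](O[C@@H]2O[C@@H](C)[C@H](OC(C)=O)[C@@H](O[C@@H]3O[C@@H](C)[C@H](OC(C)=O)[C@@H](OC(C)=O)[C@H]3O)[C@H]2OC(C)=O)[C@H]1O` likewise gives > 20 ug/mL, again a limit. Compound 3 `CCCCCCCCO[C@@H]1O[C@@H](C)[C@H](OC(=O)CCCCC)[C@@H](O[C@@H]2O[C@@H](C)[C@H](OC(C)=O)[C@@H](O)[C@H]2OC(C)=O)[C@H]1O` gives > 20 ug/mL, also a limit. For the measured compounds named here, all three values sit at the limit of > 20 ug/mL in this assay, at which 3 of the 3 values shown sit, so no step between them can be read. Compound 4 `CCCCCCCCO[C@@H]1O[C@@H](C)[C@H](OC(=O)CCCCC)[C@@H](O[C@@H]2O[C@@H](C)[C@H](OC(C)=O)[C@@H](OC(C)=O)[C@H]2OC(C)=O)[C@H]1O` differs from compound 3 by acetyl in place of hydrogen on an oxygen on a saturated carbon, hydroxy to acetoxy. Going by the values given here, no measured step guides this change, and the neighbouring compounds give only limits. Compound 4 is therefore expected to remain near that limit, with the step that the limit leaves unreadable from compound 3 to compound 4 being none beyond the scatter. The estimate for compound 4 is 30 ug/mL, ranging from 10 ug/mL to 100 ug/mL.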

Compound 4, concentration for half-maximal effect: 5.6 ug/mL
The estimate for compound 4 lay 5.4-fold (0.73 log units) above the measured number; measured number outside the range, below it.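

For the compounds shown here, compound 4 gives the first readable number in this set, whereas no step could be read among compound 1, compound 2 and compound 3. In this assay, the change from hydroxy to acetoxy gives an at least 3.5-fold lower number from compound 3 to compound 4 (0.55 log units; beyond the scatter). This size is only a minimum, and the true step may be larger, because compound 3 carries a limit rather than a number: the limit of > 20 ug/mL in this assay, at which 3 of the 4 values shown sit.

The compounds shown leave open whether the acetyl itself matters or only the loss of the free hydroxy. As far as these compounds go, how a methyl ether or an amine in this place would read also remains open.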